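A few compounds are considered here, and "the series" means these few. Any claim that something is new, unique, unknown or untested is made for them only; others in the source may bear on it.

Compounds measured in a functional assay on CHO cells with adenosine receptor A1 (Homo sapiens) as the target, read by cAMP accumulation and immunoassay, with a stated time of 6 min, tested at 0.01 uM; a higher number here means a weaker effect of the compound at the concentration tested, a lower number a stronger effect:
compound 1 `Nc1scc(CN2CCN(c3ccccc3C(F)(F)F)CC2)c1C(=O)c1ccc(Cl)cc1`: 0%
compound 2 `Nc1scc(CN2CCN(c3ccncc3)CC2)c1C(=O)c1ccc(Cl)cc1`: -4%
compound 3 `Nc1scc(CN2CCN(c3ccc(C(F)(F)F)cc3)CC2)c1C(=O)c1cccc(C(F)(F)F)c1`: -12%

Compound 3 gives -12% in this assay; compound 2 lies within the scatter of it, while compound 1 lies beyond the scatter above it. Compound 4 `Nc1scc(CN2CCN(c3cccc(F)c3)CC2)c1C(=O)c1cccc(C(F)(F)F)c1` differs from compound 3 in one place: 3-fluorophenyl in place of 4-(trifluoromethyl)phenyl on an amine nitrogen in a ring. Going by the values given here, the only measured step that also swaps the group on this ring nitrogen is a number 4 percentage points lower from compound 1 to compound 2 (within the scatter), and it stays within the scatter; neither of its groups is the pair exchanged here. With so little to go on, no step beyond the scatter is expected, a number 4 percentage points higher from compound 3 to compound 4 (within the scatter). Compound 4 is therefore estimated at -8% in this assay, with a range from -25% to 10%.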

Compound 4, a percentage reported as activity, at one concentration (the size of the read-out at that concentration, not a potency): -11%
Estimate against measurement, compound 4: 3 percentage points above; the range from low to high includes it.
By their numbers in this assay, from the lowest: compounds 3, 4, 2 and 1 (each within the scatter of the next, the first and the last beyond it).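

In this assay, the exchange on the ring nitrogen gives a number 1 percentage points higher from compound 3 to compound 4 (within the scatter), which is the first such exchange shown on the core of compound 3. The smaller 3-fluorophenyl thus replaces 4-(trifluoromethyl)phenyl with no step beyond the scatter, as also holds for the only other exchange listed at this nitrogen. No measurement shown here explains this result. As far as these compounds go, whether an amine or a carboxylic acid on this phenyl ring would move the number remains open. So does whether the same exchange behaves alike on the core of compound 1.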